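The compounds below may be only part of what the source reports. "The series", "measured", "known", "first", "only" and "open" are said of these compounds alone.

Working notes on the series. In an assay on CHO cells for agonist activity at Neuronal acetylcholine receptor; alpha3/alpha6/beta2/beta3 (Homo sapiens), read by FLIPR and calcium flux (on this read-out lower numbers stand for an effect already at smaller amounts and higher numbers for an effect only at larger amounts of compound), compound 1 `CC(C)C(=O)N1CC2CC(C1)N2` gives 16000 nM, the highest of the three numbers in hand. Compound 2 `O=C(C1CCC1)N1CC2CC(C1)N2` gives 370 nM and compound 3 `O=C(C1CC=CC1)N1CC2CC(C1)N2` gives 1900 nM; of the two, compound 3 stands nearest to compound 1 and compound 2 furthest. Among the compounds with values here, the only step measured in a single place is a 43-fold lower number from compound 1 to compound 2 (1.64 log units; beyond the scatter), a large step. Compound 4 `C[C@H]1C[C@@H]1C(=O)N1CC2CC(C1)N2` has not yet been measured. It differs from compound 1 as follows: 2-methylcyclopropyl in place of isopropyl on a carbonyl carbon. The incoming group is a ring of carbon only, as in compound 2 and compound 3, and both of those show lower numbers than compound 1 in this assay; the step from compound 1 to compound 2 bears most directly, since it too replaces isopropyl with a carbon ring on the carbonyl carbon. A downward step beyond the scatter is therefore expected for compound 4 in this assay, though the ring in compound 4 is three-membered and carries a methyl, so the full size of the step seen for compound 2 is not assumed. The expected step is a 16-fold lower number from compound 1 to compound 4 (1.20 log units; beyond the scatter). For compound 4 the estimate in this assay is 1000 nM, with a range from 200 nM to 5000 nM.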

Compound 4, half-maximal effective concentration: 3800 nM
Estimate against measurement, compound 4: 3.8-fold (0.58 log units) below; the measured number falls inside the stated range.
By their numbers in this assay, from the lowest: compound 2; then compounds 3 and 4 (each within the scatter of the next); then compound 1.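

In this assay, a second carbon ring on the carbonyl carbon also gives a lower number than isopropyl, this time 2-methylcyclopropyl, with a 4.2-fold lower number from compound 1 to compound 4 (0.62 log units; beyond the scatter). The lowering seen with cyclobutyl is therefore not unique to that ring among the compounds compared here, but its size is not shared: exchanging cyclobutyl for 2-methylcyclopropyl is itself a large change, with a 10-fold higher number from compound 2 to compound 4 (1.01 log units; beyond the scatter), so the identity of the ring matters at this place and not merely its presence. No measurement in hand gives a reason for the gap between these two rings.

The series leaves open whether that gap follows the ring size or the methyl, a question that plain cyclopropyl on the same carbonyl carbon would help separate, and how the opposite stereoisomers of 2-methylcyclopropyl would compare. Every group shown at this place is also carbon only, so the effect of a ring containing oxygen, such as tetrahydrofuranyl, or of a group carrying an amine remains unknown.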